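Acid to Butyl Amide: What to Expect for Compound 4

The compounds below may be only part of what the source reports. "The series", "measured", "known", "first", "only" and "open" are said of these compounds alone.

Measured so far in a functional assay on the whole organism (strain Wistar) for inhibition, with Rattus norvegicus as the target, read by paw edema, with stated times of 60 min and 24 h, at a dose of 100 mg/kg by the oral route; on this read-out lower numbers stand for less inhibition and higher numbers for more inhibition at the one dose given (going by the name of the read-out):
compound 1 `COc1cc2c(cc1OC)C(CC(=O)O)CC2` gives 26.7%;
compound 2 `CCNC(=O)CC1CCc2cc(OC)c(OC)cc21` gives 33.3%;
compound 3 `COc1cc2c(cc1OC)C(CC(=O)NC(C)C)CC2` gives 30%.

Compound 1 holds the lowest of the three numbers, yet both its neighbours sit within the usual scatter of it, so no ordering among the three can be claimed. Compound 4 `CCCCNC(=O)CC1CCc2cc(OC)c(OC)cc21` is not yet measured. It differs from compound 1 in one place: butylamino in place of hydroxy on a carbonyl carbon.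

Going by the values given here, two measured steps bear on this change, since each also replaces the hydroxy on the carbonyl carbon with an amine. Going to the ethylamino analogue gave a number 6.6 percentage points higher from compound 1 to compound 2 (within the scatter), and going to the isopropylamino analogue gave a number 3.3 percentage points higher from compound 1 to compound 3 (within the scatter). Between those two amides, adding a methyl on the chain carbon bound to the amide nitrogen gave a number 3.3 percentage points lower from compound 2 to compound 3 (within the scatter). Among the compounds with values here, all three steps stay inside the scatter, so the amide series so far shows no movement beyond noise.

Compound 4 is therefore expected to land near its amide relatives, with an estimated step of a number 4.3 percentage points higher from compound 1 to compound 4 (within the scatter), which is no more than scatter. The estimate for compound 4 in this assay is 31%, within a range from 19% to 43%.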

Compound 4, a percentage reported as inhibition, in the whole organism at one dose (the size of the read-out at that dose, not a potency): 36.7%
The estimate for compound 4 lay 5.7 percentage points below the measured number, within the range that was stated.
By their numbers in this assay, from the lowest: compounds 1, 3, 2 and 4 (each within the scatter of the next).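

In this assay, butylamino on the carbonyl carbon gives a number 10 percentage points higher from compound 1 to compound 4 (within the scatter) and so, like the ethylamino and isopropylamino amides, does not separate from the parent acid. This is the longest chain shown at this position, so a chain of this length on the amide nitrogen still leaves the result inside the usual spread of repeat measurements. The amides also stay together, with butyl in place of isopropyl on the amide-type nitrogen giving a number 6.7 percentage points higher from compound 3 to compound 4 (within the scatter) and ethyl in place of hydrogen on the saturated chain carbon giving a number 3.4 percentage points higher from compound 2 to compound 4 (within the scatter) in this series. No supporting data are available to explain these numbers.

With every step inside the scatter, the compounds shown leave open whether this position has any real influence on the read-out at this single dose. A longer chain such as hexylamino, a ring-bearing amine such as benzylamino, or a methyl ester on the same carbonyl carbon could test whether any replacement for hydroxy moves the number beyond the scatter.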